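Fluorine on a Phenyl in Two Related Pairs

The source may report more compounds than this note shows. Statements on the series, on what has been measured and on what is new or still open speak of the compounds shown alone.

Compound 1 `O=C(/C=C\Nc1ccc(O)cc1)c1cn(-c2ccccc2)nc1-c1ccccc1` and compound 3 `O=C(/C=C\Nc1ccc(O)cc1)c1cn(-c2ccccc2)nc1-c1ccc(F)cc1` share a core and differ in one place: fluoro in place of hydrogen on an aromatic carbon. In an ADME assay on HaCaT cells (Homo sapiens) for antiproliferative activity, read by MTT assay, with a stated time of 48 h (on this read-out higher numbers stand for weaker inhibition and lower numbers for stronger inhibition), compound 1 gives 44600 nM, while compound 3 gives 16300 nM, and the step is a 2.7-fold lower number from compound 1 to compound 3 (0.44 log units; beyond the scatter). Compound 2 `COc1cc(N/C=C\C(=O)c2cn(-c3ccccc3)nc2-c2ccccc2)cc(OC)c1OC` rests on a core whose difference from the core of compound 1 is not broken down here; in this assay compound 2 gives 36200 nM. Compound 4 `COc1cc(N/C=C\C(=O)c2cn(-c3ccccc3)nc2-c2ccc(F)cc2)cc(OC)c1OC` carries the same change relative to compound 2: fluoro in place of hydrogen on an aromatic carbon, at a place described in the same words as before. For compound 4 a step of a 2.6-fold lower number from compound 2 to compound 4 (0.41 log units; beyond the scatter) is expected, because a 2.7-fold lower number from compound 1 to compound 3 (0.44 log units; beyond the scatter) arose from this very change on a closely related core. Compound 4 is therefore estimated at 14000 nM, with a likely range from 7000 nM to 30000 nM.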

Compound 4, half-maximal inhibitory concentration: 32800 nM
Beside the measured number, compound 4's estimate is 2.3-fold (0.37 log units) below it; the whole stated range lies below it.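

In this assay the change from phenyl to 4-fluorophenyl gives a 1.1-fold lower number from compound 2 to compound 4 (0.04 log units; within the scatter), so on the core of compound 2 it has no effect that can be told apart from the usual scatter. Set beside the earlier step, this result does not differ from it by more than two such steps can differ through scatter alone: the same change on two cores in this assay, a 2.7-fold lower number (0.44 log units; beyond the scatter) from compound 1 to compound 3 and a 1.1-fold lower number (0.04 log units; within the scatter) from compound 2 to compound 4, 2.5-fold (0.39 log units) apart, within the scatter of two such steps. This does not show that the change carries over at the same size, nor that the two cores respond differently; one step lies beyond the scatter, the other within it, and two pairs cannot settle the matter.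

Still open, going by these compounds, is whether a chloro or a methyl group in the same place would move the number further. On these data alone, how the fluoro step behaves on other cores also remains open.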